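Carboxymethyl on the amide nitrogen: working notes

The source may hold more compounds than are shown below. What is called first, only, known or untested is meant among the compounds shown, and "the series" means these compounds.

Values in a functional assay on MCF7 cells (Homo sapiens) for antiproliferative activity, read by MTT assay, with a stated time of 24 h (a higher number here means a weaker inhibitor, a lower number a stronger inhibitor), are as follows
compound 1 `CCn1c(C(=O)NCCN)ccc1C(CC)(CC)c1ccc(OCS(=O)(=O)c2ccccc2)c(C)c1` gives 6470 nM
compound 2 `CCn1c(C(=O)N[C@H](CO)CCCO)ccc1C(CC)(CC)c1ccc(OCS(=O)(=O)c2ccccc2)c(C)c1` gives 31400 nM
compound 3 `CCn1c(C(=O)N[C@@H](CO)CCCO)ccc1C(CC)(CC)c1ccc(OCS(=O)(=O)c2ccccc2)c(C)c1` gives 29600 nM

Compound 3 (29600 nM) sits in the upper pair of the three values. The gap inside that pair (a 1.1-fold lower number from compound 2 to compound 3 (0.03 log units; within the scatter)) is within the scatter, while the gap to the remaining value (a 4.6-fold higher number from compound 1 to compound 3 (0.66 log units; beyond the scatter)) is beyond it.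

Compound 4 `CCn1c(C(=O)NCC(=O)O)ccc1C(CC)(CC)c1ccc(OCS(=O)(=O)c2ccccc2)c(C)c1` differs from compound 3 by one group (a group of 4 heavy atoms (2 carbon, 2 oxygen; no ring) in place of a group of 7 heavy atoms (5 carbon, 2 oxygen; no ring), on an amide-type nitrogen) and carries carboxymethyl on the amide-type nitrogen. Two modest steps on this same nitrogen bear on the change (a 4.9-fold higher number from compound 1 to compound 2 (0.69 log units; beyond the scatter) and a 4.6-fold higher number from compound 1 to compound 3 (0.66 log units; beyond the scatter)), though neither introduces carboxymethyl, so they indicate a plausible size rather than a direction. The configuration step (a 1.1-fold lower number from compound 2 to compound 3 (0.03 log units; within the scatter)) stays within the scatter alongside the fact that compounds 2 and 3 differ only in the configuration as drawn and gives no reason to expect much from the loss of the stereocentre alone.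

In this assay compound 4 is therefore expected near compound 3 (29600 nM), with no step beyond the scatter, and any drift is expected to run towards a lower number. The estimated step is a 1.5-fold lower number from compound 3 to compound 4 (0.17 log units; within the scatter) as an expectation only. For compound 4 the estimated value is 20000 nM with an expected range from 8000 nM to 50000 nM in this assay.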

Compound 4, half-maximal inhibitory concentration: 33100 nM
Beside the measured number, compound 4's estimate is 1.7-fold (0.22 log units) below it; measured number inside the range.
By their numbers in this assay, from the lowest: compound 1; then compounds 3, 2 and 4 (each within the scatter of the next).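

In this assay, carboxymethyl on the amide-type nitrogen lands level with both hydroxy-bearing chains (a 1.1-fold higher number from compound 3 to compound 4 (0.05 log units; within the scatter) and a 1.1-fold higher number from compound 2 to compound 4 (0.02 log units; within the scatter)), so this position tolerates a much shorter group carrying a carboxy end without any readable change from those larger chains. Among the compounds shown here, the one step beyond the scatter among the new comparisons is a 5.1-fold higher number from compound 1 to compound 4 (0.71 log units; beyond the scatter), where carboxy stands in place of aminomethyl on the saturated chain carbon, and this leaves compound 1 alone at the low end, with compounds 2, 3 and 4 forming a single level despite their different groups. Compound 4 has no stereocentre at all and still stays level with both drawn configurations, which carries the flat reading of that pair over to a compound without the stereocentre: the fact that compounds 2 and 3 differ only in the configuration as drawn.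

On these data alone, whether the low number of compound 1 follows the terminal amine as such remains open, since a longer chain ending in an amine, or a dimethylamino end on the same chain, would separate the amine from its chain length. A hydroxyethyl group or a methyl ester on this nitrogen would show whether the level shared by compounds 2, 3 and 4 extends to other neutral ends.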